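The compounds below may be only part of what the source reports. "The series", "measured", "known", "first", "only" and "open" are said of these compounds alone.

For the measured compounds named here, in an ADME assay (liver) for metabolic stability, with Liver microsome (Canis lupus familiaris) as the target, read by LC-MS, using microsomes, with a stated time of 30 min, tested at 4 uM (a lower number here means that less of the compound is left, a higher number that more of the compound is left), compound 3 `COc1ccccc1-c1nc2c(N3CCN(C)CC3)nc(C)nc2n1C1CCOCC1` gives 36%, which sits in the lower part of the numbers measured so far. Compound 2 `COCCn1c(-c2ccccc2Cl)nc2c(N3CCN(C(C)=O)CC3)nc(C)nc21` gives 34%, within the scatter of compound 3. Compound 1 `CCN1CCN(c2nc(C)nc3c2nc(-c2ccccc2Cl)n3CCOC)CC1` gives 86%, well above compound 3.

Compound 4 `Cc1nc(N2CCN(C)CC2)c2nc(-c3ccccc3C)n(C3CCOCC3)c2n1` differs from compound 3 at a single place: methyl in place of methoxy on an aromatic carbon. This is methyl in place of methoxy on an aromatic carbon, ortho to a large group. Going by the values given here, the only measured step between two close relatives, a number 52 percentage points lower from compound 1 to compound 2 (beyond the scatter), was large, but it is a different change: acetyl in place of ethyl on an amine nitrogen in a ring. It shows that a small edit can move this read-out strongly, yet it says nothing about direction here. Among the compounds with values here, no measured step covers methyl in place of methoxy. The expected step is a number 4 percentage points higher from compound 3 to compound 4 (within the scatter), with no firm direction and nothing expected beyond the scatter. For compound 4 the estimated value is 40%, in an expected range from 20% to 62%.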

Compound 4, percent of the compound remaining: 39%
The estimate for compound 4 lay 1 percentage points above the measured number, and the stated range covers the measured number.
By their numbers in this assay, from the lowest: compounds 2, 3 and 4 (each within the scatter of the next); then compound 1.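

Exchanging methoxy for methyl on this aromatic carbon, ortho to a large group, gives in this assay a number 3 percentage points higher from compound 3 to compound 4 (within the scatter). So, unlike the change from ethyl to acetyl on the ring nitrogen, this edit leaves the read-out without a step beyond the scatter, even though an oxygen and its hydrogen-bond acceptor leave the molecule. Nothing measured here points to what lies behind this result.

As far as these compounds go, whether an amine, a carboxylic acid or a longer chain on this same aromatic carbon would also leave the read-out in place remains open. Also open, from the compounds shown here alone, is whether methyl and methoxy would still read alike in a compound carrying the acetyl group of compound 2, where less of the compound is left than with the ethyl group of compound 1.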